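The source may report more compounds than this note shows. Statements on the series, on what has been measured and on what is new or still open speak of the compounds shown alone.

Compound 3, `COc1ccc(N2CCN(C(=S)SCc3ccc(C(=O)Nc4ccccc4N)cc3)CC2)cc1`, gives 35.9% in a functional assay on A-375 cells (Homo sapiens) for antiproliferative activity, read by CCK-8 assay, with a stated time of 72 h, tested at 8 uM (on this read-out higher numbers stand for a stronger effect at the one concentration tested and lower numbers for a weaker effect), the highest of the three numbers in hand. Compound 1, `Nc1ccccc1NC(=O)c1ccc(CSC(=S)N2CCN(c3ccc(Cl)cc3)CC2)cc1`, gives 29%, and the change a number 6.9 percentage points higher from compound 1 to compound 3 (within the scatter) sits within the scatter. Compound 2, `Nc1ccccc1NC(=O)c1ccc(CSC(=S)N2CCN(C(c3ccccc3)c3ccccc3)CC2)cc1`, gives 8.4%, and its value lies beyond the scatter below that of compound 3, though no single-step comparison between these two is available.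

Compound 4, `Nc1ccccc1NC(=O)c1ccc(CSC(=S)N2CCN(Cc3ccccc3)CC2)cc1`, differs from compound 3 by benzyl in place of 4-methoxyphenyl on an amine nitrogen in a ring. Among the measured compounds shown here, the one measured step, from chloro to methoxy on the aromatic carbon, does not touch the group on the ring nitrogen and therefore says little about this change. What the numbers show is that compound 3 and compound 1, both with an aryl group on that nitrogen, give similar values, while compound 2, with a different kind of group there, gives a lower one. The step to compound 4 is therefore expected to be downward, a number 15.9 percentage points lower from compound 3 to compound 4 (beyond the scatter), though with wide uncertainty. Compound 4 is estimated at 20%, with a range from 5% to 36%.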

Compound 4, a percentage reported as inhibition, at one concentration (the size of the read-out at that concentration, not a potency): 29.3%
Estimate against measurement, compound 4: 9.3 percentage points below, within the range that was stated.
By their numbers in this assay, from the lowest: compound 2; then compounds 1, 4 and 3 (each within the scatter of the next).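

Benzyl in place of 4-methoxyphenyl on the ring nitrogen gives a number 6.6 percentage points lower from compound 3 to compound 4 (within the scatter) in this assay and benzyl in place of 4-chlorophenyl gives a number 0.3 percentage points higher from compound 1 to compound 4 (within the scatter) on the same read-out. Among compounds 1, 3 and 4, then, an aromatic ring bound directly to that nitrogen and a benzyl group cannot be told apart. Hydrogen in place of phenyl on the saturated chain carbon gives a number 20.9 percentage points higher from compound 2 to compound 4 (beyond the scatter) and this is the first step in one place that links the lower value of compound 2 to its second phenyl.

Still open, on these data alone, is how a longer chain such as 2-phenylethyl on the ring nitrogen would read, or a group with no aromatic ring such as cyclohexyl. Nothing measured here accounts for any of these steps.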